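Swapping a cyanopyridyl amide for a glycinamide chain

The compounds below may be only part of what the source reports. "The series", "measured", "known", "first", "only" and "open" are said of these compounds alone.

The compounds share one core, shown in compound 1 `Cc1cc(C)cc(S(=O)(=O)c2c(C(=O)Nc3ccnc(C#N)c3)[nH]c3ccc(Cl)cc23)c1`, and differ only in the group on the amide-type nitrogen. In an ADME assay on MT4 cells (Homo sapiens) for cytotoxicity, read by MTT assay (a lower number here means that less compound is tolerated, a higher number that more compound is tolerated), compound 1 gives 6840 nM, the lowest of the two numbers shown. Compound 2 `Cc1cc(C)cc(S(=O)(=O)c2c(C(=O)NC(C)C(=O)NC(C)c3ccccc3F)[nH]c3ccc(Cl)cc23)c1`, which carries an alanine-linked amide chain on that nitrogen, gives 15200 nM, so more of compound 2 is tolerated than of compound 1. Compound 3 `Cc1cc(C)cc(S(=O)(=O)c2c(C(=O)Nc3cc(C#N)ccn3)[nH]c3ccc(Cl)cc23)c1` reaches only a limit of the assay, > 53700 nM. Within the data shown here, the single step measured in one place, an at least 7.8-fold higher number from compound 1 to compound 3 (0.89 log units; beyond the scatter), shows that moving the nitrile around the pyridine already raises the tolerated concentration; its size is bounded only by the limit of > 53700 nM in this assay, at which 1 of the 3 values shown sits.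

Compound 4 `Cc1cc(C)cc(S(=O)(=O)c2c(C(=O)NCC(=O)NCc3ccccc3F)[nH]c3ccc(Cl)cc23)c1` takes the change (((2-fluorobenzyl)carbamoyl)methyl in place of 2-cyanopyridin-4-yl on an amide-type nitrogen). Among the measured compounds shown here, no measured step covers exactly this change, but compound 2 holds a closely related chain and gives 15200 nM, and the one measured step away from the cyanopyridyl of compound 1 went upward. A step of similar size in the same direction is therefore expected, a 2.0-fold higher number from compound 1 to compound 4 (0.31 log units; beyond the scatter), and compound 4 is expected to give about 14000 nM in this assay, within 6000 nM to 45000 nM.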

Compound 4, half-maximal cytotoxic concentration: > 47300 nM
Compound 4: a limit, no number (the forecaster's own chance of this, stated with the estimate: 20%); middle value at least 3.3-fold (0.52 log units) from the limit.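

In this assay, putting ((2-fluorobenzyl)carbamoyl)methyl in place of 2-cyanopyridin-4-yl on the amide-type nitrogen gives an at least 6.9-fold higher number from compound 1 to compound 4 (0.83 log units; beyond the scatter), so the number at this position rises not only with another cyanopyridyl group but also with a chain ending in a ring of carbon only. The result for compound 4 is a limit of the assay and not a number, so the true size of this step stays unknown: the limit of > 47300 nM in this assay, at which 1 of the 4 values shown sits.

The result for compound 3 is also a limit of the assay, so the two groups cannot be ranked and the step between these two compounds cannot be read: the limit of > 53700 nM in this assay, at which 1 of the 4 values shown sits.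

Compound 2, with its alanine-linked chain, gives 15200 nM. The compounds shown do not settle which part of the chain in compound 4 goes with its result. From the compounds shown here alone, it also remains open whether the number stays this high with a carboxylic acid or an amine at the end of the chain in place of the 2-fluorobenzyl group, or with a longer chain on this nitrogen.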